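The source may hold more compounds than are shown below. What is called first, only, known or untested is meant among the compounds shown, and "the series" means these compounds.

Measured compounds:
compound 1, `COC(=O)c1nc(C)n(-c2ccc(F)cc2)n1`: 8700 nM
compound 2, `COC(=O)c1nc(C2CCCCC2)n(-c2ccc(F)cc2)n1`: > 100000 nM
compound 3, `COC(=O)c1nc(-c2ccoc2)n(-c2ccc(F)cc2)n1`: 9320 nM

In a functional assay on Jurkat cells (Homo sapiens) for inhibition, read by MTT assay, with a stated time of 72 h (a lower number here means a stronger inhibitor of growth, a higher number a weaker inhibitor of growth), compound 1 gives 8700 nM. For compound 2 the result is a limit of the assay, > 100000 nM, not a number (the limit of > 100000 nM in this assay, at which 1 of the 3 values shown sits). Compound 3 gives 9320 nM, the higher of the two numbers shown, with compound 1 nearest; the step of a 1.1-fold higher number from compound 1 to compound 3 (0.03 log units; within the scatter) stays within the scatter. The two large steps run through compound 2: an at least 11-fold higher number from compound 1 to compound 2 (1.06 log units; beyond the scatter) and an at least 10-fold lower number from compound 2 to compound 3 (1.03 log units; beyond the scatter).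

Compound 4, `COC(=O)c1nc(-c2ccsc2)n(-c2ccc(F)cc2)n1`, differs from compound 3 in one place: thiophen-3-yl in place of furan-3-yl on an aromatic carbon. Among the compounds with values here, no measured step exchanges one five-membered aromatic ring for another, so the expectation rests on the observation that compound 1 and compound 3 sit close together while only the cyclohexyl compound 2 stands apart. The step of a 1.2-fold lower number from compound 3 to compound 4 (0.07 log units; within the scatter) is therefore expected to lie within the scatter. Compound 4 is estimated at 8000 nM, with a likely range from 3000 nM to 25000 nM.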

Compound 4, concentration for 50% growth inhibition: 54000 nM
Estimate against measurement, compound 4: 6.8-fold (0.83 log units) below; the measured number lies above the stated range.
By their numbers in this assay, from the lowest: compounds 1 and 3 (each within the scatter of the next); then compound 4. At a limit, above all of these: compound 2.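

Swapping furan-3-yl for thiophen-3-yl on this aromatic carbon gives a 5.8-fold higher number from compound 3 to compound 4 (0.76 log units; beyond the scatter) in this assay, so the position distinguishes two five-membered aromatic rings with the same heavy-atom count, one holding oxygen and the other sulfur. Thiophen-3-yl also stands apart from methyl, with a 6.2-fold higher number from compound 1 to compound 4 (0.79 log units; beyond the scatter), whereas furan-3-yl stayed within the scatter of methyl, so an aromatic ring here is not enough to match compound 1. Compound 2 is a limit of the assay and not a number, and the step to it reads an at least 1.8-fold lower number from compound 2 to compound 4 (0.26 log units; that floor lies within the scatter), so compound 4 is not firmly separated from it.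

Nothing shown explains why this exchange moves the number so far. As far as these compounds go, how a phenyl ring, a pyridin-3-yl ring or an aminomethyl group would behave on this carbon stays open.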